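This account rests on a few compounds, and the source may have more. Where it says the series, first, only, none or still open, it means among the compounds named here.

In an ADME assay on RAW264.7 cells (Mus musculus) for cytotoxicity, read by MTT assay, with a stated time of 24 h (on this read-out lower numbers stand for higher toxicity in this test and higher numbers for lower toxicity in this test), compound 1, whose structure is `O=c1oc2ccccc2c(=O)n1-c1ccc(Cl)cc1F`, gives 26500 nM. Compound 2, with structure `COc1ccc2c(=O)n(-c3ccc(Cl)cc3F)c(=O)oc2c1`, is made from compound 1 by a single change: methoxy in place of hydrogen on an aromatic carbon. In this assay compound 2 reaches only a limit of the test, > 40000 nM. The change therefore produced an at least 1.5-fold higher number from compound 1 to compound 2 (0.17 log units; that floor lies within the scatter), and the reading for compound 2 sits at the limit of > 40000 nM in this assay, at which 1 of the 3 values shown sits, so the true size of this step is not pinned down.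

Compound 3, with structure `O=C(Nc1ccc(I)cc1F)c1ccccc1O`, is built on a different core; how the two cores differ is not broken down here. In this assay compound 3 gives 23300 nM. Compound 4, structure `COc1ccc(C(=O)Nc2ccc(I)cc2F)c(O)c1`, differs from compound 3 by methoxy in place of hydrogen on an aromatic carbon. Going by the values given here, this is the same kind of change as the one from compound 1 to compound 2, but not the same: in compound 1 the methoxy enters on a ring that is part of a fused or bridged system of two rings, meta and para to a fused ring, whereas in compound 3 it enters meta to a hydroxy group and para to a large group.

Compound 4 is expected to show a step of a 1.5-fold higher number from compound 3 to compound 4 (0.18 log units; within the scatter), a modest rise in the number, resting on the earlier step of an at least 1.5-fold higher number from compound 1 to compound 2 (0.17 log units; that floor lies within the scatter) seen with compound 1 and compound 2. Compound 4 is thus estimated at 35000 nM, between 18000 nM and 70000 nM.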

Compound 4, half-maximal cytotoxic concentration: 27600 nM
The estimate for compound 4 lay 1.3-fold (0.10 log units) above the measured number; the measured number falls inside the stated range.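

In this assay, methoxy in place of hydrogen on the core of compound 3 gives a 1.2-fold higher number from compound 3 to compound 4 (0.07 log units; within the scatter), so on this core the change has no effect that can be told apart from the ordinary variation between repeated measurements. This does not show that the change acts alike on both cores, since the reading for compound 2 is a limit of the test and not a number: the limit of > 40000 nM in this assay, at which 1 of the 4 values shown sits. Set side by side, the two cases give no firm comparison, only a pair of steps of which one has an open upper end: the same change on two cores in this assay, an at least 1.5-fold higher number (0.17 log units; that floor lies within the scatter) from compound 1 to compound 2 and a 1.2-fold higher number (0.07 log units; within the scatter) from compound 3 to compound 4; the limit leaves it open whether they differ.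

As far as these compounds go, only methoxy appears as the added group here, and it stays open whether an amine, a carboxylic acid or a longer chain on the same aromatic carbon would move the number by more than the usual scatter on either core. Also open are the true size of the step to compound 2 and the part played by the halogen, as compound 1 carries chlorine and compound 3 carries iodine, and no pair shown separates that difference from the difference in core.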